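Adding bromo to the phenyl of compound 3

The compounds below may be only part of what the source reports. "The series", "measured", "known", "first", "only" and "open" are said of these compounds alone.

Measured in a functional assay on A549 cells (Homo sapiens) for cytotoxicity, read by MTT assay, with a stated time of 72 h; a lower number here means a stronger inhibitor, a higher number a weaker inhibitor:
- compound 1 `O=S(=O)(c1ccccc1)c1nc2ccccc2nc1N1CCCC1`: 34800 nM
- compound 2 `Cc1ccc(S(=O)(=O)c2nc3ccccc3nc2N2CCc3ccccc3C2)cc1`: > 50000 nM (a limit, not a number)
- compound 3 `O=S(=O)(c1ccccc1)c1nc2ccccc2nc1N1CCCC(O)C1`: 310 nM

Compound 3 has the lower of the two numeric results in this assay, at 310 nM. The nearest number is that of compound 1, at 34800 nM. Compound 2 gives only a limit, > 50000 nM.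

The next compound, compound 4 `O=S(=O)(c1ccc(Br)cc1)c1nc2ccccc2nc1N1CCCC(O)C1`, has bromo in place of hydrogen on an aromatic carbon of a six-membered aromatic ring of carbon only, para to a large group, taking phenyl to 4-bromophenyl (bromo in place of hydrogen on an aromatic carbon).

Going by the values given here, the only measured step is a 110-fold lower number from compound 1 to compound 3 (2.05 log units; beyond the scatter). That large step puts 3-hydroxypiperidin-1-yl in place of pyrrolidin-1-yl, so it lies elsewhere in the molecule and bears only indirectly on this change. Among the compounds with values here, no measured step isolates a change on the phenyl. A modest step is therefore expected, of uncertain direction, with a slight lean towards a higher number and a wide margin. The expected step is a 1.3-fold higher number from compound 3 to compound 4 (0.11 log units; within the scatter). For compound 4 the estimated value in this assay is 400 nM, with an expected range from 90 nM to 2500 nM.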

Compound 4, half-maximal inhibitory concentration: 2100 nM
Estimate against measurement, compound 4: 5.3-fold (0.72 log units) below, within the range that was stated.
By their numbers in this assay, from the lowest: compound 3; then compound 4; then compound 1. At a limit, above all of these: compound 2.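

In this assay, the phenyl now has a measured step of its own: bromo in place of hydrogen gives a 6.8-fold higher number from compound 3 to compound 4 (0.83 log units; beyond the scatter), so this place on the ring is not indifferent to substitution, and the change here moves towards a weaker inhibitor. The only other step shown, a 110-fold lower number from compound 1 to compound 3 (2.05 log units; beyond the scatter), is graded large where this one is modest, and it lies elsewhere in the molecule, so on the two steps available the exchange of pyrrolidin-1-yl for 3-hydroxypiperidin-1-yl counts for more than this change on the phenyl. Nothing measured here bears on what lies behind the step from hydrogen to bromo.

The compounds shown leave open whether this rise belongs to bromo itself or would follow any group at this place, a question that fluoro, methoxy or a carboxylic acid in place of the same hydrogen would help to settle. Also open, on these data alone, is whether the bromo step keeps its size and direction when pyrrolidin-1-yl stands in place of 3-hydroxypiperidin-1-yl.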